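A few compounds are considered here, and "the series" means these few. Any claim that something is new, unique, unknown or untested is made for them only; others in the source may bear on it.

Of the compounds shown here, three of a shared core have been measured in a physicochemical assay for lipophilicity, using the shake flask method, measured as octanol-water partition, at pH 7.4; a lower number here means a more polar compound, a higher number a more lipophilic compound. Compound 1 `COc1cc(/C=C/C(=O)Nc2ccccc2)ccc1OCCCN1CCCCC1` gives 1.58. Compound 2 `COc1cc(/C=C/C(=O)Nc2ccccc2)ccc1OCCCCCN1CCCC1` gives 1.64. Compound 3 `COc1cc(/C=C/C(=O)Nc2ccccc2)ccc1OCCCCCCCCN(C)C` gives 1.74, the highest of the three numbers, though the steps leading to it are small: a number 0.16 log units higher from compound 1 to compound 3 (within the scatter) and a number 0.10 log units higher from compound 2 to compound 3 (within the scatter), as is the step of a number 0.06 log units higher from compound 1 to compound 2 (within the scatter) between the other two. All three changes altered the amine end of the chain, and none moved this assay beyond its scatter.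

Compound 4 `CCN(CC)CCCCCCCCOc1ccc(/C=C/C(=O)Nc2ccccc2)cc1OC` differs from compound 3 in one place: diethylamino in place of dimethylamino on a saturated chain carbon, eight bonds along the chain from an oxygen on an aromatic ring. Going by the values given here, no measured step repeats this exact exchange, so the bearing of the earlier steps is indirect. Among the compounds with values here, still, each of them reshaped the amine terminus and stayed within the scatter, with the step from compound 1 to compound 3 the largest of them, and that is the only guide available.

For compound 4 the expectation is therefore a value close to that of compound 3, perhaps slightly higher, a shift of about a number 0.26 log units higher from compound 3 to compound 4 (within the scatter) that may or may not exceed the scatter. Compound 4 is estimated at 2 in this assay, within a range from 1.6 to 2.5.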

Compound 4, partition coefficient: 1.75
Compound 4: middle estimate off by 0.25 log units, on the high side; the measured number falls inside the stated range.
By their numbers in this assay, from the lowest: compounds 1, 2, 3 and 4 (each within the scatter of the next).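

In this assay, the exchange of dimethylamino for diethylamino on a saturated chain carbon, eight bonds along the chain from an oxygen on an aromatic ring, gives a number 0.01 log units higher from compound 3 to compound 4 (within the scatter). Unlike the earlier steps, which altered the amine and the chain length together, this one leaves the chain untouched and alters only the groups on the nitrogen, and even so it stays within the scatter. The wider comparisons, a number 0.11 log units higher from compound 2 to compound 4 (within the scatter) and a number 0.17 log units higher from compound 1 to compound 4 (within the scatter), are also within the scatter, so the four compounds cannot be told apart here, and no supporting evidence is available to interpret this result.

The compounds shown leave open whether any change at the amine end would produce a step beyond the scatter, for instance dipropylamino or a morpholine ring at the same place, or a carboxylic acid in place of the amine. They also leave open how diethylamino would read on a shorter chain, where the same exchange might not give the same small step.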